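Methyl to Hydrogen on an Aromatic Oxygen: Cytotoxicity Expectation

This account rests on a few compounds, and the source may have more. Where it says the series, first, only, none or still open, it means among the compounds named here.

Measured in an ADME assay on RAW264.7 cells (Mus musculus) for cytotoxicity, read by MTT assay, with a stated time of 24 h, tested at 1.25 ug/mL; on this read-out higher numbers stand for a weaker effect at the one concentration tested and lower numbers for a stronger effect:
compound 1 `COc1cc(/C=C/C(=O)c2cccc(O)c2)ccc1O` gives 96.9%
compound 2 `COc1ccc(/C=C/C(=O)c2ccc(OC)c(OC)c2)cc1` gives 97.2%
compound 3 `COc1ccc(/C=C/C(=O)c2cccc(O)c2)cc1OC` gives 101%

All three measured compounds sit close together, and all three numbers show that the cells were left largely unaffected at the single concentration used. Compound 3 and compound 1 differ by one change, (hydrogen in place of methyl on an oxygen on an aromatic ring), and the step of a number 4.1 percentage points lower from compound 3 to compound 1 (within the scatter) is within the scatter. Compound 2 and compound 3 differ in more than one place; how their cores differ is not broken down here.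

Compound 4 `COc1ccc(/C=C/C(=O)c2ccc(O)c(OC)c2)cc1` is not yet measured. For the measured compounds named here, it differs from compound 2 by hydrogen in place of methyl on an oxygen on an aromatic ring, the same change, at the same kind of place, as the one seen between compound 3 and compound 1. Since that earlier step a number 4.1 percentage points lower from compound 3 to compound 1 (within the scatter) stayed within the scatter, the step from compound 2 to compound 4 is expected to be similarly small, a number 0.8 percentage points higher from compound 2 to compound 4 (within the scatter). Compound 4 is therefore estimated to give 98% in this assay, with a likely range from 90% to 106%.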

Compound 4, a percentage reported as activity, at one concentration (the size of the read-out at that concentration, not a potency): 96.2%
Estimate against measurement, compound 4: 1.8 percentage points above; measured number inside the range.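

The new step, in which hydrogen takes the place of methyl on an oxygen on an aromatic ring, reads in this assay as a number 1 percentage points lower from compound 2 to compound 4 (within the scatter) and is therefore small on this second core as well. Set beside the earlier step on the other core, the two results agree: the same change on two cores in this assay, a number 4.1 percentage points lower (within the scatter) from compound 3 to compound 1 and a number 1 percentage points lower (within the scatter) from compound 2 to compound 4, 3.1 percentage points apart, within the scatter of two such steps
This shows that the change carried from one core to the other in this series without a step beyond the usual scatter, but two cores cannot show that it would do so on every core, and a single concentration that leaves the cells largely unaffected gives no measure of potency.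

The compounds shown carry only methoxy and hydroxy groups at the places compared, so what an amine, a carboxylic acid or a longer chain such as ethoxy would do there remains open. Also open, as far as these compounds go, is whether the same change stays this small at concentrations where the cells are clearly affected.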